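Side-chain amine variation and microsomal stability

This account rests on a few compounds, and the source may have more. Where it says the series, first, only, none or still open, it means among the compounds named here.

Measured compounds:
compound 1 `CC(C)NCCS(=O)(=O)NC(=O)c1ccc(Nc2nc(NC3(c4ccc(Cl)cc4)CC3)nc(OCC(F)(F)F)n2)cc1`: 100%
compound 2 `O=C(NS(=O)(=O)CCNC(=O)C1CC1)c1ccc(Nc2nc(NC3(c4ccc(Cl)cc4)CC3)nc(OCC(F)(F)F)n2)cc1`: "not active" (no number reported)
compound 3 `CC(C)(C)CNCCS(=O)(=O)NC(=O)c1ccc(Nc2nc(NC3(c4ccc(Cl)cc4)CC3)nc(OCC(F)(F)F)n2)cc1`: 90%

In an ADME assay on microsomes from liver (Rattus norvegicus) for metabolic stability, with a stated time of 10 min (a lower number here means that less of the compound is left, a higher number that more of the compound is left), compound 3 stands lowest of the two reported numbers, but the step of a number 10 percentage points lower from compound 1 to compound 3 (within the scatter) lies within the scatter, so compound 1 and compound 3 cannot be ordered. Compound 2 is reported without a number.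

Compound 4 `CC(C)NC(=O)NCCS(=O)(=O)NC(=O)c1ccc(Nc2nc(NC3(c4ccc(Cl)cc4)CC3)nc(OCC(F)(F)F)n2)cc1` differs from compound 3 by isopropylcarbamoyl in place of neopentyl on an amine nitrogen. Only one measured step, from compound 1 to compound 3, bears on this position, and it was within the scatter; no listed step covers a change of this kind at the amine nitrogen. On that basis no step beyond the scatter in this assay is expected. Compound 4 is therefore estimated at 85%, range 60% to 100%. For compound 4 this estimate means a step of a number 5 percentage points lower from compound 3 to compound 4 (within the scatter).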

Compound 4, percent of the compound remaining: 97%
Compound 4: the middle estimate sits 12 percentage points below what was measured; the range from low to high includes it.
By their numbers in this assay, from the lowest: compounds 3, 4 and 1 (each within the scatter of the next).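

In this assay, isopropylcarbamoyl on the amine nitrogen gives a number 7 percentage points higher from compound 3 to compound 4 (within the scatter) and a number 3 percentage points lower from compound 1 to compound 4 (within the scatter), so no change can be read against either alkyl group. This position therefore carries a group with a carbonyl, a hydrogen-bond donor and a hydrogen-bond acceptor with an amount of compound remaining that cannot be separated from that of the isopropyl and neopentyl compounds. No measurement at hand bears on the reason for this result.

From the compounds shown here alone, whether a primary amine, a carboxylic acid or a longer chain on this nitrogen would stay within the same scatter remains open.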